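Macrocyclic ketoamide series: cytotoxicity and the amine substituent

The source may report more compounds than this note shows. Statements on the series, on what has been measured and on what is new or still open speak of the compounds shown alone.

Compound 1 `CCC[C@H](NC(=O)[C@@H]1C[C@@H]2CN1C(=O)[C@H](C(C)(C)C)NC(=O)OCCCCCCc1cccc3c1CN(C3)C(=O)O2)C(=O)C(=O)CC1CC1`: in an ADME assay on Huh-7 cells (Homo sapiens) for cytotoxicity (a lower number here means that less compound is tolerated, a higher number that more compound is tolerated), compound 1 gives > 50000 nM, a limit of the assay.
Compound 2 `CCC[C@H](NC(=O)[C@@H]1C[C@@H]2CN1C(=O)[C@H](C(C)(C)C)NC(=O)OCCCCCCc1cccc3c1CN(C3)C(=O)O2)C(=O)C(=O)NC(C)CC`: in this assay compound 2 gives > 50000 nM, likewise a limit.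

Going by the values given here, both values sit at the limit of > 50000 nM in this assay, at which 2 of the 2 values shown sit, so the one measured step that the two limits leave unreadable from compound 1 to compound 2 cannot be read. Compound 2 therefore stands only at a limit, with no number of its own. Compound 3 `CCC[C@H](NC(=O)[C@@H]1C[C@@H]2CN1C(=O)[C@H](C(C)(C)C)NC(=O)OCCCCCCc1cccc3c1CN(C3)C(=O)O2)C(=O)C(=O)NC(C)c1ccccc1` carries phenyl in place of ethyl on a saturated chain carbon bound to an amide-type nitrogen and a saturated chain carbon. Among the compounds with values here, no measured step bears on this change, and the single step available is unreadable, so no direction can be drawn from the series. Compound 3 is expected to remain at or near the limit, estimated at 60000 nM with a range of 20000 nM to 200000 nM. The expected step that the limit leaves unreadable from compound 2 to compound 3 is thus small.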

Compound 3, half-maximal cytotoxic concentration: > 50000 nM
Compound 3: only a limit was reported (the forecaster's own chance of this, stated with the estimate: 75%); the middle value lies beyond the limit too.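

The steps among compound 1, compound 2 and compound 3 cannot be read, since all three stand at a limit: the limit of > 50000 nM in this assay, at which 3 of the 3 values shown sit. On these data alone, whether any amine substituent on the shared core gives a measurable value in this assay remains open.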